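This account rests on a few compounds, and the source may have more. Where it says the series, first, only, none or still open, it means among the compounds named here.

Measured compounds:

Compound 1 `CC(C(=O)NCc1ccc(C(F)(F)F)nc1Br)c1ccc(NS(C)(=O)=O)c(F)c1` gives 169 nM in an assay on CHO cells for antagonist activity at transient receptor potential cation channel subfamily V member 1 (Homo sapiens), read by FLIPR and calcium flux; a higher number here means a weaker inhibitor, a lower number a stronger inhibitor.
Compound 2 `Cc1nc(C(F)(F)F)ccc1CNC(=O)C(C)c1ccc(NS(C)(=O)=O)c(F)c1` gives 387 nM in this assay.
Compound 3 `CC(C(=O)NCc1ccc(C(F)(F)F)nc1C1CCC(F)(F)CC1)c1ccc(NS(C)(=O)=O)c(F)c1` gives 1.5 nM in this assay.

Compound 3 has the lowest number of the three, and both steps to it are large: a 110-fold lower number from compound 1 to compound 3 (2.05 log units; beyond the scatter) and a 260-fold lower number from compound 2 to compound 3 (2.41 log units; beyond the scatter). Compound 4 `CC(C(=O)NCc1ccc(C(F)(F)F)nc1C1CC2CCC1C2)c1ccc(NS(C)(=O)=O)c(F)c1` has not yet been measured. It differs from compound 3 at one place: a group of 7 heavy atoms (7 carbon; 2 five-membered non-aromatic rings of carbon only) in place of a group of 8 heavy atoms (6 carbon, 2 fluorine; one six-membered non-aromatic ring of carbon only), on an aromatic carbon. The group enters next to the ring nitrogen, ortho to a large group and meta to a trifluoromethyl group, the same place where the 4,4-difluorocyclohexyl of compound 3 sits.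

The measured steps that bear on this change are those from compound 1 and compound 2 to compound 3, where a small group on that aromatic carbon gave way to a bulky ring. Compound 4 keeps a bulky saturated carbon group at that place, so a change of only modest size is expected in this assay, with a 2.0-fold higher number from compound 3 to compound 4 (0.30 log units; within the scatter) as the estimated step. For compound 4 the expected value is 3 nM, with a range from 1 nM to 12 nM.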

Compound 4, inhibition constant: 1.5 nM
Compound 4: middle estimate off by 2.0-fold (0.30 log units), on the high side; the measured number falls inside the stated range.
By their numbers in this assay, from the lowest: compounds 3 and 4 (each within the scatter of the next); then compound 1; then compound 2.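

At this aromatic carbon, replacing the 4,4-difluorocyclohexyl with a carbon-only group of two five-membered non-aromatic rings gives no change at the digits printed from compound 3 to compound 4 (within the scatter) in this assay, so neither the fluorine atoms nor that six-membered ring is needed to keep the number this low. The large gain over the small groups therefore appears with a second saturated ring group, with a 260-fold lower number from compound 2 to compound 4 (2.41 log units; beyond the scatter) and a 110-fold lower number from compound 1 to compound 4 (2.05 log units; beyond the scatter), and is not unique to compound 3. No evidence here explains why either ring group so far outperforms methyl or bromo.

The compounds shown leave open how much of this gain would survive with a smaller ring, such as cyclopropyl, or with an open chain, such as tert-butyl. They also leave open what a ring containing a heteroatom, such as morpholine or tetrahydropyranyl, would give at this carbon.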